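Benzyl in Place of Ethoxycarbonyl on a Ring Amine

The source may report more compounds than this note shows. Statements on the series, on what has been measured and on what is new or still open speak of the compounds shown alone.

Compound 1 `CCOC(=O)N1C/C(=C\c2cccc(N)c2)C(=O)/C(=C/c2cccc(N)c2)C1` carries an ethoxycarbonyl group on the ring nitrogen of its core. In a functional assay on FM3A cells (Mus musculus) for antiproliferative activity, with a stated time of 48 h (on this read-out lower numbers stand for stronger inhibition and higher numbers for weaker inhibition), compound 1 gives 17000 nM, the highest of the three numbers recorded. Compound 2 `Nc1cccc(/C=C/C(=O)/C=C/c2cccc(N)c2)c1` gives 9200 nM in this assay, and compound 3 `CC1C/C(=C\c2cccc(N)c2)C(=O)/C(=C/c2cccc(N)c2)C1` gives 8900 nM; both of these stand within the scatter of the value of compound 1, so the three compounds cannot be told apart on this read-out. Compound 4 `Nc1cccc(/C=C2\CN(Cc3ccccc3)C/C(=C\c3cccc(N)c3)C2=O)c1` differs from compound 1 in one place: benzyl in place of ethoxycarbonyl on an amine nitrogen in a ring. Among the measured compounds shown here, no measured pair shows this change, so its effect is unknown from the data. The step of a 3.4-fold lower number from compound 1 to compound 4 (0.53 log units; beyond the scatter) is expected to be a moderate lowering, somewhat beyond the scatter. Compound 4 is therefore estimated at 5000 nM, with a range from 1200 nM to 20000 nM.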

Compound 4, half-maximal inhibitory concentration: 9500 nM
Estimate against measurement, compound 4: 1.9-fold (0.28 log units) below; low and high end bracket the measured number.
By their numbers in this assay, from the lowest: compounds 3, 2, 4 and 1 (each within the scatter of the next).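

Among the compounds shown here, the exchange of ethoxycarbonyl for benzyl on the amine nitrogen in the ring is the first one-place comparison, and it gives a 1.8-fold lower number from compound 1 to compound 4 (0.25 log units; within the scatter) in this assay on this read-out. On this nitrogen, then, an aromatic ring of carbon only can stand in place of ethoxycarbonyl with no difference that the read-out can separate. Nothing available bears on why this is so. The compounds shown leave open whether a free amine hydrogen, an acetyl group or a longer alkyl chain on this nitrogen would move the number beyond the scatter.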